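Swapping a chloroethenyl for a dithiolane on a deoxyuridine

The source may hold more compounds than are shown below. What is called first, only, known or untested is meant among the compounds shown, and "the series" means these compounds.

The set comprises four nucleoside-like compounds, three with results in an ADME assay on L1210/0 cells (Mus musculus) for cytotoxicity, with a stated time of 48 h (a higher number here means a weaker inhibitor, a lower number a stronger inhibitor), and one awaiting its number. Compound 1 `O=c1[nH]cnc2c1nnn2C1C[C@H](CO)[C@@H](CO)[C@@H]1CO` and compound 3 `Nc1nc2c(nc(N)n2COCCO)c(=O)[nH]1` share no scaffold with the others. In this assay compound 1 returns only a limit, > 200000 nM. Compound 3 likewise returns a limit in this assay, > 200000 nM. Going by the values given here, compound 2 `C=C(Cl)c1cn([C@H]2C[C@H](O)[C@@H](CO)O2)c(=O)[nH]c1=O` is the one member with a real number: in this assay compound 2 gives 1660 nM, the sole measured value in the set, with the other two compounds sitting at the limit of > 200000 nM in this assay, at which 2 of the 3 values shown sit.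

Compound 4 `O=c1[nH]c(=O)n([C@H]2C[C@H](O)[C@@H](CO)O2)cc1C1SCCS1` keeps the whole of compound 2 except for one change: a group of 5 heavy atoms (3 carbon, 2 sulfur; one five-membered non-aromatic ring with 2 hetero atoms) in place of a group of 3 heavy atoms (2 carbon, 1 chlorine; no ring), on an aromatic carbon. Among the compounds with values here, no step between two measured compounds exists here, so the size of this change cannot be read from a precedent. The chloroethenyl of compound 2 is replaced by a five-membered non-aromatic ring with 2 hetero atoms, and the expectation is that the step from compound 2 to compound 4 in this assay weakens inhibition beyond the usual scatter, perhaps markedly, with a fair chance that compound 4 itself ends at the limit.

Compound 4 is therefore estimated at 50000 nM in this assay, within a range of 5000 nM to 200000 nM, which corresponds to an expected step of a 30-fold higher number from compound 2 to compound 4 (1.48 log units; beyond the scatter).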

Compound 4, half-maximal inhibitory concentration: > 200000 nM
Compound 4: only a limit was reported; the forecaster's own chance of this, stated with the estimate: 40%; middle value at least 4.0-fold (0.60 log units) from the limit.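

In this assay, going by these compounds alone, the first step in this set shows that the value at this aromatic carbon depends strongly on the group it carries: with the rest of compound 2 unchanged, the exchange of the 1-chloroethenyl for the five-membered non-aromatic ring with 2 hetero atoms gives an at least 120-fold higher number from compound 2 to compound 4 (2.08 log units; beyond the scatter). Compound 4 gives > 200000 nM, which is a limit and not a number, so this step has a lower bound but no exact size. Within the data shown here, compound 2 thus remains the only member with a real number, and a measurable value in this set now traces to one group at this position: the limit of > 200000 nM in this assay, at which 3 of the 4 values shown sit.

This single pair cannot separate the contributions of the chlorine, the double bond outside aromatic rings, the ring and the sulfur atoms, since all of them change at once. It also leaves open whether a plain ethenyl, an ethyl chain or a bromine atom at this position would keep a measurable value or would likewise end at the limit.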